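A methyl-1,2-oxazole swapped for its isomer

The compounds below may be only part of what the source reports. "The series", "measured", "known", "first", "only" and "open" are said of these compounds alone.

In a functional assay on the whole organism with Rattus norvegicus as the target (a lower number here means that less compound is needed, a higher number that more compound is needed for the effect), compound 2 `CCOCCOC(=O)C(=O)Nc1nc(-c2conc2C)cs1` gives only a limit, > 100 mg/kg. Compound 1 `CCOCCOC(=O)C(=O)Nc1nc(-c2cc(Cl)no2)cs1` also gives only a limit, > 30 mg/kg. Compound 3 `CCOCCOC(=O)C(=O)Nc1nc(-c2cc(C)on2)cs1` has the same atoms as compound 2, joined differently: 5-methyl-1,2-oxazol-3-yl in place of 3-methyl-1,2-oxazol-4-yl on an aromatic carbon. Among the measured compounds shown here, the one measured step bearing on this change is a step that the two limits leave unreadable from compound 1 to compound 2, which also exchanges the group on that aromatic carbon but offers no usable size or direction. No change beyond the scatter is therefore expected in this assay. The expected result is a number no higher from compound 2 to compound 3 (the limit leaves the size open). For compound 3 the estimate is 100 mg/kg, with an expected range of 20 mg/kg to 300 mg/kg.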

Compound 3, dose for half-maximal effect: 2 mg/kg
Compound 3: middle estimate off by 50-fold (1.70 log units), on the high side; measured number outside the range, below it.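

Exchanging 3-methyl-1,2-oxazol-4-yl for 5-methyl-1,2-oxazol-3-yl, with the same atoms joined differently, gives in this assay an at least 50-fold lower number from compound 2 to compound 3 (1.69 log units; beyond the scatter). Putting the same group in place of 3-chloro-1,2-oxazol-5-yl gives an at least 15-fold lower number from compound 1 to compound 3 (1.17 log units; beyond the scatter). This aromatic carbon therefore responds to how the ring is joined, which the earlier step could not show, since its two limits leave it unreadable.

Going by these compounds, the full size of the first step stays open, because compound 2 rests on a limit: the limit of > 100 mg/kg in this assay, at which 1 of the 3 values shown sits. Also open is whether an ethyl group in place of the 5-methyl would keep this low number.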